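The compounds below may be only part of what the source reports. "The series", "measured", "known", "first", "only" and "open" are said of these compounds alone.

Measured in an ADME assay on MT4 cells (Homo sapiens) for cytotoxicity, read by MTT assay; on this read-out higher numbers stand for lower toxicity in this test and lower numbers for higher toxicity in this test:
- Compound 1 `Cc1ccc(CNC(=O)c2[nH]c3ccc(Cl)cc3c2S(=O)(=O)c2cc(C)cc(C)c2)cc1`: 21200 nM
- Compound 2 `COc1ccc(CNC(=O)c2[nH]c3ccc(Cl)cc3c2S(=O)(=O)c2cc(C)cc(C)c2)cc1`: 39900 nM
- Compound 3 `Cc1cc(C)cc(S(=O)(=O)c2c(C(=O)NCc3ccc(Cl)cc3)[nH]c3ccc(Cl)cc23)c1`: > 51200 nM

The entry for compound 3 is a limit of the assay and not a number. Compound 3 stands at the limit of > 51200 nM in this assay, at which 1 of the 3 values shown sits.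

The next compound to consider is compound 4 `Cc1cc(C)cc(S(=O)(=O)c2c(C(=O)NCc3ccccc3F)[nH]c3ccc(Cl)cc23)c1`. Its change from compound 3 is this: 2-fluorophenyl in place of 4-chlorophenyl on a saturated chain carbon bound to an amide-type nitrogen. In words, 2-fluorophenyl takes the place of 4-chlorophenyl on a saturated chain carbon bound to an amide-type nitrogen.

The three measured steps all swap one group on an aromatic carbon of this same part of the molecule, so they are the nearest guide. Methoxy in place of methyl gave a 1.9-fold higher number from compound 1 to compound 2 (0.27 log units; within the scatter). Chloro in place of methoxy gave an at least 1.2-fold higher number from compound 2 to compound 3 (0.10 log units; that floor lies within the scatter). Chloro in place of methyl gave an at least 2.4-fold higher number from compound 1 to compound 3 (0.38 log units; beyond the scatter), the only step beyond the scatter. Going by the values given here, none of the measured compounds carries fluorine, so this guide is indirect.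

Compound 4 gives up the chloro group brought in by an at least 2.4-fold higher number from compound 1 to compound 3 (0.38 log units; beyond the scatter), so a modest move towards a lower number in this assay is expected, possibly no larger than the scatter. The expected change is an at least 1.4-fold lower number from compound 3 to compound 4 (0.16 log units; that floor lies within the scatter). For compound 4 the estimated value is 35000 nM, with an expected range from 15000 nM to 70000 nM.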

Compound 4, half-maximal cytotoxic concentration: > 53000 nM
Compound 4 ended at the assay's limit; the forecaster's own chance of this, stated with the estimate: 35%; middle value at least 1.5-fold (0.18 log units) away from the limit.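

Compound 4 ends at a limit of the assay and not a number in this assay: the limit of > 53000 nM in this assay, at which 1 of the 4 values shown sits.

The 2-fluorophenyl group thus reaches such a limit just as 4-chlorophenyl does, so on this saturated chain carbon bound to an amide-type nitrogen, that outcome does not rest on the 4-chlorophenyl group alone. Measured against 4-methylphenyl, the new group gives an at least 2.5-fold higher number from compound 1 to compound 4 (0.39 log units; beyond the scatter), and measured against 4-methoxyphenyl, it gives an at least 1.3-fold higher number from compound 2 to compound 4 (0.12 log units; that floor lies within the scatter).

With compound 3 also ending at a limit of the assay, the step between compound 3 and compound 4 cannot be read, and which of the two groups gives the higher number stays unknown: the limit of > 51200 nM in this assay, at which 1 of the 4 values shown sits.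

Also open, on these data alone, is whether 4-fluorophenyl would behave like 2-fluorophenyl, and how far the number would move with an amine or a carboxylic acid on this ring in place of the halogen.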